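Pyridin-4-yl for pyridin-2-yl on the styryl arm

The compounds below may be only part of what the source reports. "The series", "measured", "known", "first", "only" and "open" are said of these compounds alone.

Compound 1, `O=C(NCc1ccccc1)c1cc(Oc2ccc(/C=C/c3ccccn3)cc2)ccn1`, gives 18800 nM in a functional assay on A549 cells (Homo sapiens) for antiproliferative activity, read by CCK-8 assay, with a stated time of 48 h; on this read-out lower numbers stand for stronger inhibition and higher numbers for weaker inhibition.
Compound 2, `O=C(NCc1ccc(F)cc1)c1cc(Oc2ccc(/C=C/c3ccccn3)cc2)ccn1`, gives > 100000 nM in this assay, which is a limit of the assay rather than a number.
Compound 3, `O=C(NC1CC1)c1cc(Oc2ccc(/C=C/c3ccccn3)cc2)ccn1`, gives 17300 nM in this assay.

The three measured compounds share one core and differ only at the amide nitrogen. Compound 2 stands at the weak end: its value is a limit, and the limit of > 100000 nM in this assay, at which 1 of the 3 values shown sits, describes where it sits. The steps of an at least 5.3-fold higher number from compound 1 to compound 2 (0.72 log units; beyond the scatter) and an at least 5.7-fold lower number from compound 2 to compound 3 (0.76 log units; beyond the scatter) are both beyond the scatter, while a 1.1-fold lower number from compound 1 to compound 3 (0.04 log units; within the scatter) is within it.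

Compound 4, `O=C(NCc1ccc(F)cc1)c1cc(Oc2ccc(/C=C/c3ccncc3)cc2)ccn1`, is not yet measured. It is reached from compound 2 by the change (pyridin-4-yl in place of pyridin-2-yl on a double-bonded chain carbon bound to a double-bonded chain carbon). For the measured compounds named here, none of the measured steps touches this part of the molecule; all three concern the amide substituent. The expectation for compound 4 therefore rests only on compound 2, whose result is a limit, so no step beyond the scatter is expected in this assay. Compound 4 is estimated at 100000 nM, in the range 30000 nM to 300000 nM, meaning an expected step of a number no higher from compound 2 to compound 4 (the limit leaves the size open).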

Compound 4, half-maximal inhibitory concentration: 18200 nM
Estimate against measurement, compound 4: 5.5-fold (0.74 log units) above, outside the stated range (below it).
By their numbers in this assay, from the lowest: compounds 3, 4 and 1 (each within the scatter of the next). At a limit, above all of these: compound 2.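

For the compounds shown here, the change from pyridin-2-yl to pyridin-4-yl is the first one on the styryl arm, and in this assay it gives an at least 5.4-fold lower number from compound 2 to compound 4 (0.73 log units; beyond the scatter). The read-out therefore responds to this part of the molecule as well as to the amide substituent, and it does so between two groups with the same atoms and the same counts under comparison. Compound 2 stands at a limit, so this step gives only a bound on the size of the change: the limit of > 100000 nM in this assay, at which 1 of the 4 values shown sits.

As far as these compounds go, the change is seen here only with the 4-fluorobenzyl amide, so whether it carries over to the benzyl or cyclopropyl amides remains open. Also open, from the compounds shown here alone, is how pyridin-3-yl, or a plain phenyl ring, would read at this place.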